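This account rests on a few compounds, and the source may have more. Where it says the series, first, only, none or still open, it means among the compounds named here.

Measured compounds in an ADME assay on 184B5 cells (Homo sapiens) for cytotoxicity, read by sulforhodamine B assay, with a stated time of 48 h; on this read-out higher numbers stand for weaker inhibition of growth and lower numbers for stronger inhibition of growth:
compound 1 `CCN(CC)CN1C(=O)/C(=N\c2nc3ccc(C)cc3s2)c2ccccc21` gives 27500 nM;
compound 2 `CCN(CC)CN1C(=O)/C(=N\c2nc3ccc(C)cc3s2)c2c(Br)cccc21` gives 34300 nM;
compound 3 `O=C1C(=O)N(CN(c2ccccc2)c2ccccc2)c2ccccc21` gives 33700 nM.

Among the compounds with values here, compound 2 sits within the usual scatter of both of the other two numbers: its step from compound 1, a 1.2-fold higher number from compound 1 to compound 2 (0.10 log units; within the scatter), is the only single-point change among the measured set, and the number of compound 3 lies at almost the same place without a single-point relation to it. Compound 4 `Cc1ccc2nc(/N=C3\C(=O)N(CN(C)C)c4cccc(Br)c43)sc2c1` differs from compound 2 by dimethylamino in place of diethylamino on a saturated chain carbon bound to an amide-type nitrogen in a ring. Within the data shown here, no measured step touches this part of the molecule; the one step available, from compound 1 to compound 2, concerns bromo in place of hydrogen on an aromatic carbon and stayed within the scatter. The three numbers together show no movement beyond the scatter across the changes covered, so the expectation for the amine change is likewise a step of no size beyond the scatter in this assay, that is a 1.0-fold lower number from compound 2 to compound 4 (0.00 log units; within the scatter). Compound 4 is therefore estimated at 34000 nM, with a range from 15000 nM to 75000 nM.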

Compound 4, concentration for 50% growth inhibition: 74800 nM
Beside the measured number, compound 4's estimate is 2.2-fold (0.34 log units) below it; low and high end bracket the measured number.
By their numbers in this assay, from the lowest: compounds 1, 3 and 2 (each within the scatter of the next); then compound 4.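

In this assay, within the data shown here, replacing diethylamino with dimethylamino on a saturated chain carbon bound to an amide-type nitrogen in a ring gives a 2.2-fold higher number from compound 2 to compound 4 (0.34 log units; beyond the scatter), the only step in the set that lies beyond the scatter. This position therefore responds to a change where the bromo-for-hydrogen step did not, and the shift is toward weaker inhibition of growth, though this rests on a single pair of compounds. Nothing in the data given accounts for the step.

From the compounds shown here alone, it remains open whether the same amine change would move the number similarly on compound 1, which carries hydrogen in place of the bromo. Going by these compounds, it is also open how a dipropylamino group or a ring amine such as morpholine would behave at this place, so no trend can yet be drawn across amines.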